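Swapping a Saturated Ring for a Halogenated Phenyl

The source may report more compounds than this note shows. Statements on the series, on what has been measured and on what is new or still open speak of the compounds shown alone.

Four compounds share one core that carries a nitro group on a fused ring system; they differ in the side arm attached to it. Compound 1, `C[C@]1(CN2CCc3oc(-c4ccc(F)cc4)nc3C2)Cn2cc([N+](=O)[O-])nc2O1`, carries a fluorophenyl group on its arm. In an ADME assay on Vero cells (Chlorocebus sabaeus) for cytotoxicity, read by MTT assay, with a stated time of 72 h (a lower number here means that less compound is tolerated, a higher number that more compound is tolerated), compound 1 gives > 32 ug/mL, and this value is a limit of the measurement, not a number. Compound 2, `C[C@]1(CN2CCn3nc(-c4ccc(F)c(F)c4)nc3C2)Cn2cc([N+](=O)[O-])nc2O1`, carries a difluorophenyl group; in this assay compound 2 gives "not determined" (no result reported). Compound 3, `C[C@]1(CN2CCc3nc(C4CCOCC4)ccc3C2)Cn2cc([N+](=O)[O-])nc2O1`, carries an oxan-4-yl group on its arm; in this assay compound 3 gives "not determined" (no result reported). So compound 3 stands without a number of its own: among the three entries shown, one is only a limit, as recorded in the limit of > 32 ug/mL in this assay, at which 1 of the 3 values shown sits, and one other also gives no number.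

Compound 4, `C[C@]1(CN2CCc3nc(-c4ccc(F)c(Cl)c4)ccc3C2)Cn2cc([N+](=O)[O-])nc2O1`, is the compound that has not yet been measured. It differs from compound 3 in one place: 3-chloro-4-fluorophenyl in place of oxan-4-yl on an aromatic carbon.

Within the data shown here, with no measured step between any two compounds, the size of the change in this assay cannot be read from the data, and the only anchor is the limit reached by compound 1. Compound 4 is therefore expected to be tolerated to about 32 ug/mL, within a range from 10 ug/mL to 64 ug/mL.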

Compound 4, half-maximal cytotoxic concentration: > 32 ug/mL
Compound 4 was reported as a limit (the forecaster's own chance of this, stated with the estimate: 65%); the middle value sits exactly at the limit.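

No step can be read between compound 3 and compound 4: compound 3 has no number of its own in this assay, and the result for compound 4 is a limit, not a number. The compounds shown leave open what replacing oxan-4-yl with 3-chloro-4-fluorophenyl does to the read-out in this assay.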